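Trifluoromethyl in place of methoxymethoxy: working notes

The source may hold more compounds than are shown below. What is called first, only, known or untested is meant among the compounds shown, and "the series" means these compounds.

- compound 1 `O=C1OC[C@H](Cc2ccccc2)[C@H]1Cc1ccccc1O`: 83000 nM
- compound 2 `COCOc1ccccc1C[C@H]1C(=O)OC[C@@H]1Cc1ccccc1`: 76000 nM
- compound 3 `Cc1ccccc1C[C@H]1C(=O)OC[C@@H]1Cc1ccccc1`: 57000 nM

In a functional assay on HL-60 cells (Homo sapiens) for cytotoxicity, read by WST assay, with a stated time of 48 h (a higher number here means that more compound is needed for the effect, a lower number that less compound is needed), compound 2 gives 76000 nM, which is not separated from either neighbour: a 1.1-fold lower number from compound 1 to compound 2 (0.04 log units; within the scatter), and a 1.3-fold lower number from compound 2 to compound 3 (0.12 log units; within the scatter). The next analogue is compound 4 `O=C1OC[C@H](Cc2ccccc2)[C@H]1Cc1ccccc1C(F)(F)F`. The change is trifluoromethyl in place of methoxymethoxy on an aromatic carbon, ortho to a large group.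

The measured steps that bear on this change are those at the same aromatic carbon. The closest is the replacement of methoxymethoxy by methyl, a 1.3-fold lower number from compound 2 to compound 3 (0.12 log units; within the scatter). The replacement of hydroxy by methyl, a 1.5-fold lower number from compound 1 to compound 3 (0.16 log units; within the scatter), is also relevant. None of the three compounds departs from the others beyond the scatter, and none of them carries trifluoromethyl. No step beyond the scatter is therefore expected in this assay, and no direction is favoured. The estimated step is a 1.3-fold lower number from compound 2 to compound 4 (0.10 log units; within the scatter). For compound 4 the expected value is 60000 nM, with an estimated range of 30000 nM to 110000 nM.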

Compound 4, half-maximal effective concentration: 37000 nM
For compound 4 the middle estimate is 1.6-fold (0.21 log units) above the measured one; measured number inside the range.
By their numbers in this assay, from the lowest: compounds 4, 3, 2 and 1 (each within the scatter of the next, the first and the last beyond it).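

In this assay, this aromatic carbon now gives steps beyond the scatter, though only modest ones, when trifluoromethyl replaces methoxymethoxy (a 2.1-fold lower number from compound 2 to compound 4 (0.31 log units; beyond the scatter)) or hydroxy (a 2.2-fold lower number from compound 1 to compound 4 (0.35 log units; beyond the scatter)); methyl had not separated from either group. Trifluoromethyl and methyl themselves remain unseparated (a 1.5-fold lower number from compound 3 to compound 4 (0.19 log units; within the scatter)), so the two cannot be ordered at this position. No measurement shown accounts for the difference between these groups.

The four compounds leave open whether the separation from hydroxy and methoxymethoxy is specific to trifluoromethyl or would also appear with other replacements at this carbon. A chlorine atom, a primary amine or a carboxylic acid at the same carbon would widen the comparison beyond these four groups, and each could be read against compound 3 and compound 4.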